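This account rests on a few compounds, and the source may have more. Where it says the series, first, only, none or still open, it means among the compounds named here.

Among the measured compounds shown here, compound 1 `O=c1ccoc2cc(OCc3cn(Cc4ccc(Cl)cc4)nn3)ccc12` is the weaker of the two measured compounds: in a functional assay on QGY7701 cells (Homo sapiens) for cytotoxicity, read by MTT assay, with a stated time of 48 h (a lower number here means a stronger inhibitor, a higher number a weaker inhibitor), compound 1 gives 41700 nM, while compound 2 `O=c1ccoc2cc(OCc3cn(Cc4ccc(Cl)cc4Cl)nn3)ccc12` gives 13300 nM, and the step of a 3.1-fold lower number from compound 1 to compound 2 (0.50 log units; beyond the scatter) is the only measured change so far. Compound 3 `N#Cc1cccc(Cn2cc(COc3ccc4c(=O)ccoc4c3)nn2)c1` differs from compound 1 by 3-cyanophenyl in place of 4-chlorophenyl on a saturated chain carbon bound to an aromatic nitrogen. For the measured compounds named here, no measured step exchanges one aromatic ring for another, and the single measured step adds a chloro rather than replacing one, so it does not bear directly on this change; compound 3 is therefore expected to sit near compound 1, a step of a 1.1-fold higher number from compound 1 to compound 3 (0.03 log units; within the scatter) that may stay within the scatter. The value of compound 3 is estimated at 45000 nM, from 15000 nM to 130000 nM.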

Compound 3, half-maximal inhibitory concentration: 24400 nM
Estimate against measurement, compound 3: 1.8-fold (0.27 log units) above; the range from low to high includes it.
By their numbers in this assay, from the lowest: compounds 2, 3 and 1 (each within the scatter of the next, the first and the last beyond it).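

In this assay, 3-cyanophenyl in place of 4-chlorophenyl on a saturated chain carbon bound to an aromatic nitrogen gives a step within the scatter (a 1.7-fold lower number from compound 1 to compound 3 (0.23 log units; within the scatter)), and so does its exchange for 2,4-dichlorophenyl (a 1.8-fold higher number from compound 2 to compound 3 (0.26 log units; within the scatter)). This position therefore takes a nitrile-bearing ring with no difference beyond the scatter from either chlorinated compound, although compound 1 and compound 2 lie beyond the scatter of each other. No measured finding explains this result. From the compounds shown here alone, whether an amine or a carboxylic acid in place of the nitrile would fall in the same range remains open, as does the effect of a longer chain at this place.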